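From 4-chlorophenyl to phenethyl on a sulfur

The source may hold more compounds than are shown below. What is called first, only, known or untested is meant among the compounds shown, and "the series" means these compounds.

Compound 1 `Nc1ccccc1NC(=O)/C=C/c1ccc(CSc2ccc(Cl)cc2)cc1`: 55.3%
Compound 2 `Nc1ccccc1NC(=O)c1ccc(CSc2ccc(C(F)(F)F)cn2)cc1`: 37.1%

Both compounds were tested in a functional assay on A549 cells (Homo sapiens) for inhibition, read by CCK-8 assay, with a stated time of 72 h, tested at 2 uM; on this read-out lower numbers stand for less inhibition of growth and higher numbers for more inhibition of growth at the one concentration tested. There compound 1 gives 55.3% and compound 2 gives 37.1%, which places compound 1 higher of the two by a gap beyond the usual scatter. Within the data shown here, these two compounds differ in more than one place, and no measured pair isolates a single change.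

Compound 3 `Nc1ccccc1NC(=O)/C=C/c1ccc(CSCCc2ccccc2)cc1` keeps the core of compound 1 but carries phenethyl in place of 4-chlorophenyl on a sulfur. The chlorine goes, while the new group still holds one six-membered aromatic ring of carbon only. Among the measured compounds shown here, with no measured precedent for this swap, the expectation starts from compound 1 at 55.3% and remains loose. The estimated step of a number 6.3 percentage points lower from compound 1 to compound 3 (within the scatter) is a small expected fall, none beyond the scatter. Compound 3 is expected to reach 49%, with an estimated range from 30% to 67%.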

Compound 3, percent growth inhibition at one concentration: 45.7%
Compound 3: the middle estimate sits 3.3 percentage points above what was measured, within the range that was stated.
By their numbers in this assay, from the lowest: compounds 2, 3 and 1 (each within the scatter of the next, the first and the last beyond it).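

In this assay, among these compounds, phenethyl in place of 4-chlorophenyl on a sulfur is the first single change that can be read on its own, and it amounts to a number 9.6 percentage points lower from compound 1 to compound 3 (within the scatter). The sulfur of the core of compound 1 can therefore carry a group without chlorine, with its aromatic ring held on a saturated chain instead of attached directly to the sulfur, and the read-out at this one concentration shows no difference that stands clear of the usual scatter. That is all one step can say about this position, and nothing measured here offers an explanation for the result.

This swap removes the chlorine and adds the chain in one move, so plain phenyl and 4-chlorophenethyl on the same sulfur would be needed to tell the two parts apart. Benzyl would test a shorter link to the ring, while a chain ending in an amine or a carboxylic acid would show whether this position also accepts a group without an aromatic ring.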